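The source may hold more compounds than are shown below. What is called first, only, known or untested is meant among the compounds shown, and "the series" means these compounds.

Working notes on the series, read in a functional assay on HCT-15 cells (Homo sapiens) for inhibition, read by sulforhodamine B assay, with a stated time of 48 h; a higher number here means a weaker inhibitor of growth, a lower number a stronger inhibitor of growth. Compound 1 (`O=C(Cc1csc2nc(-c3ccc(Br)cc3)cn12)N/N=C/c1ccccc1`) gives > 100000 nM, which is a limit of the assay and not a number. Within the data shown here, compound 2 (`O=C(Cc1csc2nc(-c3ccc(Br)cc3)cn12)N/N=C/c1ccccc1O`) gives 17400 nM, so the series has one numeric value so far. The next compound to read is compound 3 (`O=C(Cc1csc2nc(-c3ccc(Br)cc3)cn12)N/N=C/c1ccc(O)cc1`), which differs from compound 1 by hydroxy in place of hydrogen on an aromatic carbon, para to a large group. Among the measured compounds shown here, only one measured step bears on this change, an at least 5.7-fold lower number from compound 1 to compound 2 (0.75 log units; beyond the scatter), which is the same kind of change though not at the same place. On that single step, with compound 2 as its basis, a move to a lower number is expected in this assay, of similar or smaller size. The expected step is an at least 2.8-fold lower number from compound 1 to compound 3 (0.45 log units; beyond the scatter). For compound 3 the estimate is 35000 nM, with an expected range of 12000 nM to 100000 nM.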

Compound 3, concentration for total growth inhibition: 61700 nM
Estimate against measurement, compound 3: 1.8-fold (0.25 log units) below, and the stated range covers the measured number.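

In this assay, phenyl to 4-hydroxyphenyl gives an at least 1.6-fold lower number from compound 1 to compound 3 (0.20 log units; that floor lies within the scatter), so at this place the change is not shown to lower the number by more than the usual scatter. Where the hydroxy sits does register, however, since 4-hydroxyphenyl in place of 2-hydroxyphenyl gives a 3.5-fold higher number from compound 2 to compound 3 (0.55 log units; beyond the scatter), a step that is read between two numeric values and so gives the series its first firm comparison. The true size of the step to 4-hydroxyphenyl stays unfixed, and compound 1 holds a limit of the assay and not a number: the limit of > 100000 nM in this assay, at which 1 of the 3 values shown sits.

Going by these compounds, whether the lower number of 2-hydroxyphenyl depends on the hydroxy itself remains open, as a methoxy group or an amine at that place would test this. Also open, on these data alone, is how either hydroxy would read on a core carrying another group in place of the bromine.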